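This account rests on a few compounds, and the source may have more. Where it says the series, first, only, none or still open, it means among the compounds named here.

Measured compounds:
Compound 1, `COc1ccccc1/C=c1/[nH]c(=O)/c(=C\c2cccc(Cl)c2Cl)[nH]c1=O`: "not active" (no number reported)
Compound 2, `C=CCn1c(=O)/c(=C\c2ccccc2OC)[nH]c(=O)/c1=C\c1ccccc1OC`: 21200 nM

In a functional assay on Huh-7 cells (Homo sapiens) for cytotoxicity, read by CCK-8 assay, with a stated time of 72 h (on this read-out higher numbers stand for weaker inhibition and lower numbers for stronger inhibition), compound 2 gives 21200 nM. In the same read-out compound 1 gives "not active" (no number reported), with no number attached. Compound 2 therefore stands as the only quantified entry in this assay; there is one further entry without a single number, and no ordering among the measured compounds can be drawn from this.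

Compound 3, `COc1ccccc1/C=c1/[nH]c(=O)/c(=C\c2ccccc2OC)[nH]c1=O`, is to be measured in this assay. It differs from compound 2 by hydrogen in place of allyl on an aromatic nitrogen, in words hydrogen in place of allyl on an aromatic nitrogen. For the measured compounds named here, no step between measured compounds that differ in one place is available, so the size of this change is not calibrated within the set. Going by the values given here, what can be said is that compound 1, which also carries hydrogen rather than allyl on its core nitrogens, returned no number, while the allyl-bearing compound 2 is the only compound with a value. On that basis the step is expected to move toward weaker inhibition, with a fair chance that only a limit is reported. The expected step is a 2.1-fold higher number from compound 2 to compound 3 (0.33 log units; beyond the scatter). For compound 3 the estimate in this assay is 45000 nM, within a range from 15000 nM to 120000 nM.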

Compound 3, half-maximal inhibitory concentration: "not active" (no number reported)
Compound 3: no number reported, so the estimate cannot be set against anything.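

In this assay, for the compounds shown here, compound 3 gives "not active" (no number reported) and so no step from compound 2 can be read. No measured property bears on this result. The compounds shown leave open how large a change hydrogen in place of allyl on an aromatic nitrogen makes in this assay.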